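Fluoro for methoxy on the cinnamoyl ring of compound 3

The source may report more compounds than this note shows. Statements on the series, on what has been measured and on what is new or still open speak of the compounds shown alone.

Compound 1 `COc1ccc(-c2nnc(NC(=O)/C=C/c3ccccc3)s2)cc1`: 0.68 ug/mL
Compound 2 `O=C(/C=C/c1ccc(F)cc1)Nc1nnc(-c2ccc(Br)cc2)s1`: 2.83 ug/mL
Compound 3 `COc1ccc(/C=C/C(=O)Nc2nnc(-c3ccc(OC)cc3)s2)cc1`: 0.52 ug/mL

In a functional assay on A549 cells (Homo sapiens) for antiproliferative activity, read by MTT assay, with a stated time of 48 h (on this read-out lower numbers stand for stronger inhibition and higher numbers for weaker inhibition), compound 3 gives the lowest of the three numbers, though compound 1 sits within the scatter of it; compound 2 lies well above both. Compound 4 `COc1ccc(-c2nnc(NC(=O)/C=C/c3ccc(F)cc3)s2)cc1` differs from compound 3 by fluoro in place of methoxy on an aromatic carbon. Within the data shown here, the one step known for the same position, a 1.3-fold lower number from compound 1 to compound 3 (0.12 log units; within the scatter), was small, so removing the methoxy is expected to cost little. Among the measured compounds shown here, compound 2, which carries the fluoro but also a bromo on the other ring, is the only fluoro-bearing comparator and stands far higher, but no single-change step links it to compound 3. A modest rise is therefore expected, a 1.6-fold higher number from compound 3 to compound 4 (0.21 log units; within the scatter), and compound 4 is estimated at 0.85 ug/mL, ranging from 0.4 ug/mL to 1.8 ug/mL.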

Compound 4, half-maximal inhibitory concentration: 0.75 ug/mL
Compound 4: middle estimate off by 1.1-fold (0.05 log units), on the high side, and the stated range covers the measured number.
By their numbers in this assay, from the lowest: compounds 3, 1 and 4 (each within the scatter of the next); then compound 2.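

In this assay this position, para to a large group, proves tolerant: with a 1.4-fold higher number from compound 3 to compound 4 (0.16 log units; within the scatter) and a 1.1-fold higher number from compound 1 to compound 4 (0.04 log units; within the scatter) as its steps, methoxy, fluoro and hydrogen on this carbon cannot be told apart. Among these compounds, the one new step beyond the scatter, a 3.8-fold lower number from compound 2 to compound 4 (0.58 log units; beyond the scatter), belongs to the other ring, where methoxy replaces bromo. Nothing available explains either result. As far as these compounds go, whether an amine or a carboxylic acid on the fluoro-bearing carbon would be tolerated equally remains open, as does whether groups other than methoxy on the other ring would match it.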